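This account rests on a few compounds, and the source may have more. Where it says the series, first, only, none or still open, it means among the compounds named here.

In a functional assay on SGC-7901 cells (Homo sapiens) for cytotoxicity, read by MTT assay, with a stated time of 48 h (a lower number here means a stronger inhibitor, a higher number a weaker inhibitor), three compounds of this series have been measured so far, and each is reported only as a limit of the assay rather than as a number.

Compound 1 `Cc1cccc(Cn2cc(COc3ccc4c(=O)ccoc4c3)nn2)c1` gives > 100000 nM in this assay, a limit.
Compound 2 `O=c1ccoc2cc(OCc3cn(Cc4ccc(Cl)cc4)nn3)ccc12` gives > 100000 nM in this assay, a limit.
Compound 3 `O=c1ccoc2cc(OCc3cn(Cc4ccc(Br)cc4)nn3)ccc12` gives > 100000 nM in this assay, a limit.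

Compound 3 therefore stands where the other two stand, at the limit (the limit of > 100000 nM in this assay, at which 3 of the 3 values shown sit). The steps that lead to it, a step that the two limits leave unreadable from compound 1 to compound 3 and a step that the two limits leave unreadable from compound 2 to compound 3, cannot be sized, and the same holds for a step that the two limits leave unreadable from compound 1 to compound 2. The change now considered is nitro in place of bromo on an aromatic carbon, giving compound 4 `O=c1ccoc2cc(OCc3cn(Cc4ccc([N+](=O)[O-])cc4)nn3)ccc12`. Of the measured steps, the exchange of one group on the same aromatic carbon in a step that the two limits leave unreadable from compound 2 to compound 3 is the closest relative, and it was left unreadable by the two limits. Among the measured compounds shown here, no measured step gives a direction here, so the expectation for a step that the limit leaves unreadable from compound 3 to compound 4 is a step that cannot be distinguished from none. Compound 4 is accordingly expected to sit near the limit again, with an estimate of 150000 nM in this assay, in a range from 40000 nM to 500000 nM.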

Compound 4, half-maximal inhibitory concentration: > 100000 nM
Compound 4: a limit, no number; the forecaster's own chance of this, stated with the estimate: 80%; the middle value is on the limit's open side.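

Compound 4 also gives only a limit in this assay, so no step among compound 1, compound 2, compound 3 and compound 4 can be read: the limit of > 100000 nM in this assay, at which 4 of the 4 values shown sit.

The compounds shown leave open how 3-methylphenyl, 4-chlorophenyl, 4-bromophenyl and 4-nitrophenyl rank against one another, and whether any of them gives a numerical half-maximal inhibitory concentration in this assay.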